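The compounds below may be only part of what the source reports. "The series", "measured", "known", "first", "only" and "open" are said of these compounds alone.

Measured so far, in a functional assay on RPMI-8226 cells (Homo sapiens) for inhibition; on this read-out lower numbers stand for stronger inhibition and higher numbers for weaker inhibition:
- compound 1 `N#CC1CN1C(=O)Nc1ccc(Cl)c(Cl)c1`: 2700 nM
- compound 2 `CC(=O)c1cccc(NC(=O)N2CC2C#N)c1`: 9600 nM
- compound 3 `N#CC1CN1C(=O)Nc1cccnc1`: 15000 nM

Compound 2 holds the second highest of the three numbers. Its nearest neighbour is compound 3, whose number lies within the usual scatter of that of compound 2, so no order between these two can be read. Compound 1 stands furthest away, with a lower number beyond the scatter, and is therefore the clearer inhibitor of the three.

Compound 4 `N#CC1CN1C(=O)Nc1ccccc1` has not been measured. It differs from compound 2 in one place: hydrogen in place of acetyl on an aromatic carbon. The acetyl group on the aromatic ring is lost and only a hydrogen remains. For the measured compounds named here, no pair of measured compounds shows the effect of such a removal, so no step of this kind is known in this assay .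

Expectation: the step from compound 2 to compound 4 is estimated as a 1.4-fold higher number from compound 2 to compound 4 (0.13 log units; within the scatter), that is a small rise in the number or none beyond the scatter. Compound 4 is estimated at 13000 nM, with a range from 4500 nM to 40000 nM.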

Compound 4, half-maximal inhibitory concentration: 8000 nM
Compound 4: the middle estimate sits 1.6-fold (0.21 log units) above what was measured, within the range that was stated.
By their numbers in this assay, from the lowest: compound 1; then compounds 4, 2 and 3 (each within the scatter of the next).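

In this assay, for the compounds shown here, hydrogen in place of acetyl on this aromatic carbon gives a 1.2-fold lower number from compound 2 to compound 4 (0.08 log units; within the scatter), the only step so far that isolates a single change. At this position, the acetyl group, with its 3 heavy atoms and 1 hydrogen-bond acceptor, is therefore not needed to retain the inhibition seen with compound 2, as its removal leaves the number within the scatter. No measured information is available to explain this result.

From the compounds shown here alone, whether an amine, a carboxylic acid or a longer chain at this position would move the number beyond the scatter remains open. Also open, going by these compounds, is whether acetyl placed elsewhere on the aromatic ring would give a similarly small step.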